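This account rests on a few compounds, and the source may have more. Where it says the series, first, only, none or still open, it means among the compounds named here.

Compound 1 `O=C(/C=C\Nc1ccc(F)cc1)c1nc(-c2ccc(C(F)(F)F)cc2)n2ccccc12` carries a trifluoromethyl-bearing aryl on its shared core and a 4-fluorophenyl on the amine nitrogen. In a functional assay on HCT-116 cells (Homo sapiens) for cytotoxicity, read by MTT assay, with a stated time of 48 h (on this read-out lower numbers stand for stronger inhibition and higher numbers for weaker inhibition), compound 1 gives > 30000 nM, which is a limit of the assay rather than a measured number. Two neighbours sit in the same place. Compound 2 `COc1ccc(N/C=C\C(=O)c2nc(-c3ccc(F)cc3)n3ccccc23)cc1OC` gives > 30000 nM in this assay, again a limit. Compound 3 `COc1ccc(-c2nc(C(=O)/C=C\Nc3ccc(F)cc3)c3ccccn23)cc1` gives > 30000 nM in this assay, also a limit. Compound 3 differs from compound 1 by a methoxy in place of trifluoromethyl on an aromatic carbon, and the step that the two limits leave unreadable from compound 1 to compound 3 cannot be sized because the limit of > 30000 nM in this assay, at which 3 of the 3 values shown sit, holds every value shown.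

Compound 4 `O=C(/C=C\Nc1ccc2cc[nH]c2c1)c1nc(-c2ccc(C(F)(F)F)cc2)n2ccccc12` changes the other end of compound 1: 1H-indol-6-yl in place of 4-fluorophenyl on an amine nitrogen. Among the measured compounds shown here, no measured step touches the amine nitrogen, and the one measured step is unreadable, so no direction can be expected beyond the scatter. Compound 4 is therefore expected to give about 30000 nM in this assay, in the range 8000 nM to 100000 nM. This is the expected step of a number no higher from compound 1 to compound 4 (the limit leaves the size open).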

Compound 4, half-maximal inhibitory concentration: > 30000 nM
Compound 4 was reported as a limit; the forecaster's own chance of this, stated with the estimate: 65%; the middle value sits exactly at the limit.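

In this assay compound 4 ends at a limit just as compound 1 does, so the change on the amine nitrogen between them cannot be sized: the limit of > 30000 nM in this assay, at which 4 of the 4 values shown sit.

The compounds shown leave open which change to the shared core, if any, would bring a value inside the range of this read-out.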